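Adding a Methoxy Group to a Growth Inhibitor

This account rests on a few compounds, and the source may have more. Where it says the series, first, only, none or still open, it means among the compounds named here.

Compound 1 `COc1ccc(C(=O)n2c(-c3cn(C)c4ccccc34)nc3ccccc32)cc1` and compound 2 `COc1ccc(C(=O)n2c(-c3cn(C)c4ccccc34)nc3ccccc32)cc1OC` share one core; compound 3 `COc1ccc2c(c1)c(-c1nc3ccccc3n1C(=O)c1ccccc1)cn2C` and compound 4 `COc1ccc2c(c1)c(-c1nc3ccccc3n1C(=O)c1ccccc1OC)cn2C` share another, and the difference between the two cores is not broken down here. In a functional assay on MCF7 cells (Homo sapiens) for inhibition, read by MTT assay, with a stated time of 24 h (on this read-out higher numbers stand for weaker inhibition of growth and lower numbers for stronger inhibition of growth), compound 1 gives 16300 nM, compound 2 gives 10200 nM and compound 3 gives 38400 nM. The change methoxy in place of hydrogen on an aromatic carbon brought a 1.6-fold lower number from compound 1 to compound 2 (0.20 log units; within the scatter). Compound 4 carries the same kind of change, (methoxy in place of hydrogen on an aromatic carbon), but the surroundings differ: in compound 2 the entering methoxy is ortho to a methoxy group and meta to a large group, whereas in compound 4 it is ortho to a large group. Because the earlier step was a 1.6-fold lower number from compound 1 to compound 2 (0.20 log units; within the scatter), a similarly small step is expected from compound 3 to compound 4, a 1.3-fold lower number from compound 3 to compound 4 (0.11 log units; within the scatter). Compound 4 is therefore estimated at 30000 nM, expected to lie between 12000 nM and 75000 nM.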

Compound 4, concentration for 50% growth inhibition: 23900 nM
Compound 4: the middle estimate sits 1.3-fold (0.10 log units) above what was measured; low and high end bracket the measured number.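

In this assay the entry of methoxy gives a 1.6-fold lower number from compound 3 to compound 4 (0.21 log units; within the scatter) and so remains a small step on this second core. Set beside the step on the first core, the two agree: the same change on two cores in this assay, a 1.6-fold lower number (0.20 log units; within the scatter) from compound 1 to compound 2 and a 1.6-fold lower number (0.21 log units; within the scatter) from compound 3 to compound 4, 1.0-fold (0.00 log units) apart, within the scatter of two such steps. This shows that the change behaved alike on these two cores, but since both steps lie within the scatter, it does not show that methoxy truly strengthens growth inhibition, and two cores cannot establish a rule for the whole series.

The compounds shown leave open whether a different group at these places, such as an amine, a carboxylic acid or a longer chain like butoxy, would give a larger step. They also leave open whether methoxy would behave the same way on any further core.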